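Aryl swap on the anilino nitrogen of compound 1

The source may hold more compounds than are shown below. What is called first, only, known or untested is meant among the compounds shown, and "the series" means these compounds.

Measured so far:
compound 1 `COc1cc(N(CC2CC2)c2ccc(Cl)c(Cl)c2)cnc1C(=O)[C@H]1C[C@@H]1C(=O)O` — 4.94 nM
compound 2 `COc1nc(C(=O)[C@@H]2C[C@H]2C(=O)O)ncc1N(CC1CC1)c1ccc(Cl)c2ccccc12` — 15.5 nM
compound 3 `COc1cc(N(CC(C)(C)O)c2cccc(C(F)(F)F)c2)cnc1C(=O)[C@H]1C[C@@H]1C(=O)O` — 31.8 nM

In an assay for inhibition of leukotriene C4 synthase (Homo sapiens), read by LC-MS, with stated times of 15 min and 30 min (a higher number here means a weaker inhibitor, a lower number a stronger inhibitor), compound 1 gives the lowest number of the three, and its gaps to compound 2 and to compound 3 both lie beyond the scatter, so compound 1 is the strongest inhibitor shown. Compound 4 `COc1cc(N(CC2CC2)c2cc(Cl)ccc2F)cnc1C(=O)[C@H]1C[C@@H]1C(=O)O` is not yet measured. It differs from compound 1 in one place: 5-chloro-2-fluorophenyl in place of 3,4-dichlorophenyl on a nitrogen on an aromatic ring. For the measured compounds named here, no measured pair covers this change, so its size is unknown. A modest weakening is expected, beyond the scatter but not large, since the two aryl groups match in atom count and lack donors and acceptors. The step from compound 1 to compound 4 in this assay is estimated at a 2.4-fold higher number from compound 1 to compound 4 (0.39 log units; beyond the scatter). Compound 4 is expected to give 12 nM, within 4 nM to 40 nM.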

Compound 4, half-maximal inhibitory concentration: 3.71 nM
Beside the measured number, compound 4's estimate is 3.2-fold (0.51 log units) above it; the measured number lies below the stated range.
By their numbers in this assay, from the lowest: compounds 4 and 1 (each within the scatter of the next); then compound 2; then compound 3.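

In this assay the step to 5-chloro-2-fluorophenyl in place of 3,4-dichlorophenyl on the nitrogen is a 1.3-fold lower number from compound 1 to compound 4 (0.12 log units; within the scatter) and so shows no loss at this position. The 3,4-dichlorophenyl group is therefore not required for a low number on the core of compound 1, something compound 2 and compound 3 could not show, as each differs from compound 1 in more than one place. No measurement shown accounts for this result.

As far as these compounds go, it remains open whether the chlorine or the fluorine matters more here, and how a phenyl ring bearing a nitrile or an amine on this nitrogen would read.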